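The source may report more compounds than this note shows. Statements on the series, on what has been measured and on what is new or still open speak of the compounds shown alone.

Of the compounds shown here, three built on a shared core have been measured so far in a functional assay on MCF7 cells (Homo sapiens) for inhibition, with a stated time of 48 h, tested at 50 uM; a higher number here means more inhibition of growth at the concentration tested, a lower number less inhibition of growth. Compound 1 (`C=C[C@@](C)(/C=C/c1ccc(OC(=O)CC)cc1)CCC=C(C)C`) gives 23%, and compound 2 (`C=C[C@@](C)(/C=C/c1ccc(OC(=O)CCCCCCCCC)cc1)CCC=C(C)C`) gives 10%. Compound 3 (`COc1ccccc1/C=C/[C@@](C)(/C=C/c1ccc(O)cc1)CCC=C(C)C`) stands highest of the three at 42%, and its gaps to both of the others lie beyond the scatter.

The next compound, compound 4 (`COc1ccc(/C=C/[C@@](C)(/C=C/c2ccc(O)cc2)CCC=C(C)C)cc1`), has the same atoms as compound 3, joined differently: 4-methoxyphenyl in place of 2-methoxyphenyl on a double-bonded chain carbon bound to a double-bonded chain carbon. In words, 4-methoxyphenyl sits in place of 2-methoxyphenyl on a double-bonded chain carbon bound to a double-bonded chain carbon.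

For the measured compounds named here, only one measured step exists between compounds that differ in one place: a number 13 percentage points lower from compound 1 to compound 2 (beyond the scatter). That modest step beyond the scatter comes from adding heptyl on a saturated chain carbon, which is not the place that changes here. Going by the values given here, it therefore offers no direct guide to this swap, and no measured pair compares these two groups. With no evidence for a direction, the starting point remains compound 3 at 42%.

The expected change is small, within the scatter: a number 4 percentage points lower from compound 3 to compound 4 (within the scatter). The estimated value for compound 4 is 38%, with an expected range from 20% to 55%.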

Compound 4, percent growth inhibition at one concentration: 55%
Estimate against measurement, compound 4: 17 percentage points below; measured number inside the range.
By their numbers in this assay, from the lowest: compound 2; then compound 1; then compound 3; then compound 4.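

Replacing 2-methoxyphenyl with 4-methoxyphenyl on a double-bonded chain carbon bound to a double-bonded chain carbon gives, in this assay, a number 13 percentage points higher from compound 3 to compound 4 (beyond the scatter). For the compounds shown here, the earlier step concerned only a saturated chain carbon, so this is the first sign that the reading also responds to a change at this place, even though the two groups have identical counts of heavy atoms, hydrogen-bond donors and hydrogen-bond acceptors; those counts alone therefore do not separate them here. Nothing available explains why the two groups give different readings.

This is a single pair of compounds, so the compounds shown leave open how a plain phenyl group would read at this place, or a ring carrying a chlorine or a hydroxyl in place of the methoxy. They also leave open whether the same swap would give a step of similar size if the hydroxyl on the other ring were replaced by the longer ester chain of compound 2.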